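The source may report more compounds than this note shows. Statements on the series, on what has been measured and on what is new or still open speak of the compounds shown alone.

Measured so far:
compound 1, `CN(C)C(=O)c1cc2cnc(Nc3ccc(S(=O)(=O)NCCCCN=C=S)cc3)nc2n1C1CCCC1`: 72.7%
compound 2, `CN(C)C(=O)c1cc2cnc(Nc3ccc(C(=O)NCCCN=C=S)cc3)nc2n1C1CCCC1`: 91.2%

In a functional assay on NCI-H1299 cells (Homo sapiens) for inhibition, read by CCK-8 assay, with a stated time of 72 h, tested at 10 uM (on this read-out higher numbers stand for a stronger effect at the one concentration tested and lower numbers for a weaker effect), compound 1 gives 72.7%, the lower of the two numbers, while compound 2 gives 91.2%. Compound 3, `CN(C)C(=O)c1cc2cnc(Nc3ccc(C(=O)NCCCCCCN=C=S)cc3)nc2n1C1CCCC1`, differs from compound 1 in one place: a group of 12 heavy atoms (8 carbon, 2 nitrogen, 1 oxygen, 1 sulfur; no ring) in place of a group of 11 heavy atoms (5 carbon, 2 nitrogen, 2 oxygen, 2 sulfur; no ring), on an aromatic carbon. Going by the values given here, the only measured step, a number 18.5 percentage points higher from compound 1 to compound 2 (beyond the scatter), exchanged the same group on that aromatic carbon for a related one and was modest. Compound 3 makes the same kind of exchange with a longer chain, so a rise of similar size is expected, a number 12.3 percentage points higher from compound 1 to compound 3 (beyond the scatter). Compound 3 is therefore estimated at 85%, within a range of 65% to 97%.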

Compound 3, a percentage reported as inhibition, at one concentration (the size of the read-out at that concentration, not a potency): 85%
For compound 3 middle estimate and measured number coincide at the digits printed; low and high end bracket the measured number.
By their numbers in this assay, from the lowest: compound 1; then compounds 3 and 2 (each within the scatter of the next).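

In this assay, a second amide-linked chain gives a number 12.3 percentage points higher from compound 1 to compound 3 (beyond the scatter), so the rise seen with compound 2 is not confined to one chain length. Within the amide series, exchanging one chain length for the other gives a number 6.2 percentage points lower from compound 2 to compound 3 (within the scatter), so these two chain lengths cannot be told apart here. No measured evidence accounts for either step.

Compound 1 differs from the amide compounds in both its sulfonamide link and its chain length, so those two effects remain unseparated. On these data alone, whether a much longer chain would keep this effect also stays open, as does whether an amine could replace the isothiocyanate.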